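Enlarging the aryl group at the saturated ring carbon

This account rests on a few compounds, and the source may have more. Where it says the series, first, only, none or still open, it means among the compounds named here.

Compound 1 `N#CC1=C(N)N(c2ccc(S(N)(=O)=O)cc2)C2=C(CCCC2)C1c1ccc(O)cc1` is the reference point of this short series. For the measured compounds named here, in a functional assay on Ehrlich cells (Mus musculus) for cytotoxicity, read by trypan blue exclusion, with a stated time of 2 h, tested at 10 ug/mL (a higher number here means a stronger effect of the compound at the concentration tested, a lower number a weaker effect), compound 1 gives 20%, the lowest of the two numbers measured so far; its nearest neighbour is compound 2 `N#CC1=C(N)N(c2ccc(S(N)(=O)=O)cc2)C2=C(CCCC2)C1/C=C/c1ccccc1`, which in this assay gives 50%. Going by the values given here, the one measured step, a number 30 percentage points higher from compound 1 to compound 2 (beyond the scatter), puts 2-phenylethenyl in place of 4-hydroxyphenyl on a saturated ring carbon.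

Compound 3 `N#CC1=C(N)N(c2ccc(S(N)(=O)=O)cc2)C2=C(CCCC2)C1c1c(O)ccc2ccccc12` is not yet measured. It differs from compound 1 by 2-hydroxynaphthalen-1-yl in place of 4-hydroxyphenyl on a saturated ring carbon. The step from compound 1 to compound 2 is the only one that bears on this, since it also removes 4-hydroxyphenyl from the same saturated ring carbon, though what enters there is a different group. On that basis a modest rise is expected rather than a fall, but with less confidence than for a repeat of the measured change. For compound 3 a step of a number 15 percentage points higher from compound 1 to compound 3 (beyond the scatter) in this assay is expected. Compound 3 is therefore estimated at 35%, with a range from 15% to 55%.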

Compound 3, a percentage reported as activity, at one concentration (the size of the read-out at that concentration, not a potency): 10%
For compound 3 the middle estimate is 25 percentage points above the measured one; the whole stated range lies above it.
By their numbers in this assay, from the lowest: compounds 3 and 1 (each within the scatter of the next); then compound 2.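

Putting 2-hydroxynaphthalen-1-yl in place of 4-hydroxyphenyl on the saturated ring carbon gives a number 10 percentage points lower from compound 1 to compound 3 (within the scatter) in this assay, so the second six-membered aromatic ring of carbon only leaves the two compounds indistinguishable in this read-out. Putting 2-hydroxynaphthalen-1-yl in place of 2-phenylethenyl at the same carbon gives a number 40 percentage points lower from compound 2 to compound 3 (beyond the scatter), which shows that the read-out at this position depends on which group enters, and that a larger group with more heavy atoms does not by itself bring the number up to that of compound 2. No available evidence accounts for the separation of compound 2 from compounds 1 and 3.

Compound 2 differs from the other two both in its ethenyl link and in carrying no hydroxyl on its aromatic ring, so the compounds shown do not separate these two features. A plain phenyl, a 4-methoxyphenyl or a 2-(4-hydroxyphenyl)ethenyl group at this carbon would bear on that question, and the compounds shown also leave open how an amine on the aromatic ring would behave here.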